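Changing the ring on the double bond of compound 1

The compounds below may be only part of what the source reports. "The series", "measured", "known", "first", "only" and "open" are said of these compounds alone.

Compound 1 `CSc1ccc(/C=C(/SCc2ccc(C)cc2)C(=O)c2ccc(Cl)cc2)cc1` gives 25000 nM in a functional assay on DU-145 cells (Homo sapiens) for inhibition, read by trypan blue exclusion, with a stated time of 96 h (a lower number here means a stronger inhibitor of growth, a higher number a weaker inhibitor of growth), where it stands level with compound 3 `CSc1ccc(/C=C(/SCc2ccc(Cl)cc2)C(=O)c2ccc(Cl)cc2)cc1` at 25000 nM; no change at the digits printed from compound 1 to compound 3 (within the scatter). Compound 2 `CSc1ccc(/C=C(/SCc2ccc(C)cc2)C(=O)c2ccc(Br)cc2)cc1` reaches only a limit of this assay, > 100000 nM, as the limit of > 100000 nM in this assay, at which 1 of the 3 values shown sits, records. an at least 4.0-fold higher number from compound 1 to compound 2 (0.60 log units; beyond the scatter). Compound 4 `Cc1ccc(CS/C(=C/c2ccccc2Br)C(=O)c2ccc(Cl)cc2)cc1` differs from compound 1 in another place: 2-bromophenyl in place of 4-(methylsulfanyl)phenyl on a double-bonded chain carbon bound to a double-bonded chain carbon. Among the compounds with values here, both measured steps alter the ring attached to the carbonyl or the ring on the sulfur, so neither tests this ring directly; they show only that small changes here move the number modestly or not at all. For compound 4 a modest change in either direction is expected, a 1.4-fold higher number from compound 1 to compound 4 (0.15 log units; within the scatter), giving an estimate of 35000 nM, within 8000 nM to 100000 nM.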

Compound 4, concentration for 50% growth inhibition: 10000 nM
For compound 4 the middle estimate is 3.5-fold (0.54 log units) above the measured one; low and high end bracket the measured number.
By their numbers in this assay, from the lowest: compound 4; then compounds 1 and 3 (each within the scatter of the next). At a limit, above all of these: compound 2.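

In this assay, the ring on the double bond can move the number, with a 2.5-fold lower number from compound 1 to compound 4 (0.40 log units; beyond the scatter). This is the only step shown that lowers the number, and it shows that the 4-(methylsulfanyl)phenyl group is not needed for growth inhibition at this level. Nothing in the data shown accounts for this gain.

Going by these compounds, whether it comes from gaining the bromine or from losing the methylsulfanyl group stays open. On these data alone, how a plain phenyl ring, or a ring carrying an amine or a carboxylic acid, would behave here also remains unknown.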